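This account rests on a few compounds, and the source may have more. Where it says the series, first, only, none or still open, it means among the compounds named here.

Working notes on the series.

Compound 1 `COc1cc(OC)cc(-c2cccc(NC(=O)CCc3cccc4c3COB4O)c2)c1` is the reference point. In a functional assay on HCT-116 cells (Homo sapiens) for antiproliferative activity, read by MTT assay, with a stated time of 72 h (a lower number here means a stronger inhibitor, a higher number a weaker inhibitor), compound 1 gives 50000 nM. Compound 2 `CC(=O)c1ccc(-c2cccc(NC(=O)CCc3cccc4c3COB4O)c2)cc1` keeps the amide-linked chain and differs from compound 1 only in the distal aryl group, (4-acetylphenyl in place of 3,5-dimethoxyphenyl on an aromatic carbon). In this assay compound 2 gives 48000 nM; the step of a 1.0-fold lower number from compound 1 to compound 2 (0.02 log units; within the scatter) shows that the two cores are interchangeable here within the measurement scatter.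

Compound 3 `COc1cc(OC)cc(-c2cccc(NC(=O)CCc3ccccc3)c2)c1` carries the core of compound 1 but with the chain terminus altered, (a group of 6 heavy atoms (6 carbon; one six-membered aromatic ring of carbon only) in place of a group of 10 heavy atoms (7 carbon, 1 boron, 2 oxygen; one five-membered non-aromatic ring with 2 hetero atoms, one six-membered aromatic ring of carbon only), on a saturated chain carbon, two bonds along the chain from a carbonyl carbon). For compound 3 this assay reports only a limit, > 100000 nM, at the limit of > 100000 nM in this assay, at which 1 of the 3 values shown sits. The step of an at least 2.0-fold higher number from compound 1 to compound 3 (0.30 log units; that floor lies within the scatter) is therefore known only as a floor, and that floor itself lies within the scatter, so the direction of the step is supported but its true size is not.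

Compound 4 `CC(=O)c1ccc(-c2cccc(NC(=O)CCc3ccccc3)c2)cc1` is not yet measured. It relates to compound 2 as compound 3 relates to compound 1: a group of 6 heavy atoms (6 carbon; one six-membered aromatic ring of carbon only) in place of a group of 10 heavy atoms (7 carbon, 1 boron, 2 oxygen; one five-membered non-aromatic ring with 2 hetero atoms, one six-membered aromatic ring of carbon only), on a saturated chain carbon, two bonds along the chain from a carbonyl carbon, the same change at the same place. Since the cores of compound 1 and compound 2 behaved alike in this assay, the step from compound 2 to compound 4 is expected to resemble the step from compound 1 to compound 3, that is a 2.5-fold higher number from compound 2 to compound 4 (0.40 log units; beyond the scatter), with the result most likely ending as a limit rather than a number. On that basis compound 4 is estimated at 120000 nM in this assay, with a range from 45000 nM to 400000 nM.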

Compound 4, half-maximal inhibitory concentration: 4000 nM
For compound 4 the middle estimate is 30-fold (1.48 log units) above the measured one; the measured number lies below the stated range.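

In this assay, phenyl in place of the boron-containing group on the saturated chain carbon gives a 12-fold lower number from compound 2 to compound 4 (1.08 log units; beyond the scatter), so on this core the replacement is a clear gain, and the result does not match the one on the core of compound 1: the same change on two cores in this assay, an at least 2.0-fold higher number (0.30 log units; that floor lies within the scatter) from compound 1 to compound 3 and a 12-fold lower number (1.08 log units; beyond the scatter) from compound 2 to compound 4, at least 24-fold (1.38 log units) apart, beyond the scatter of two such steps

Compound 3 gives > 100000 nM, which is a limit of the assay and not a number: the limit of > 100000 nM in this assay, at which 1 of the 4 values shown sits.

The change therefore cannot be carried from one core to the other in this series as a fixed increment, even though the boron-containing pair sits close together, with a 1.0-fold lower number from compound 1 to compound 2 (0.02 log units; within the scatter). The data do not show the true size of the step on the core of compound 1, and they do not explain the mismatch. Only two cores are shown, and which of the two results would be the more typical is not known.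

Open, from the compounds shown here alone, is whether a third core, for instance one with a carboxylic acid or an amine on the outer aryl ring in place of 4-acetylphenyl, would follow the result of compound 4 or that of compound 3. Also open, going by these compounds, is whether a longer chain between the carbonyl and the phenyl would keep the gain seen in compound 4.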